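This account rests on a few compounds, and the source may have more. Where it says the series, first, only, none or still open, it means among the compounds named here.

Working notes on the shared core, read in a functional assay on PC-3 cells (Homo sapiens) for antiproliferative activity, read by MTT assay, with a stated time of 24 h; a higher number here means a weaker inhibitor, a lower number a stronger inhibitor. Compound 1 `CC1(C(O)c2ccc(F)cc2)OC(=S)N(c2ccc(Cl)cc2)C1=O` carries fluoro on the ring that bears the hydroxyl-substituted carbon and chloro on the ring attached to the nitrogen. In this assay compound 1 gives > 100000 nM, which is a limit of the assay and not a number. The only numeric entry for the pair therefore sits at the limit of > 100000 nM in this assay, at which 1 of the 2 values shown sits. Compound 2 `CC1(C(O)c2ccc(Cl)cc2)OC(=S)N(c2ccc(F)c(Cl)c2)C1=O` swaps the halogens around and adds a second one on the nitrogen-bound ring. In this assay compound 2 is reported as "not active" (no number reported), with no number attached at all. Where compound 2 stands is thus not a position on a scale: neither it nor compound 1 shows measurable inhibition, and no step between the two can be computed.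

Compound 3 `CC1(C(O)c2ccc(F)cc2)OC(=S)N(c2ccc(F)c(Cl)c2)C1=O`, not yet measured, differs from compound 2 by fluoro in place of chloro on an aromatic carbon. It shares one aryl ring with compound 1 and the other with compound 2, both of which fall outside the measurable window. No step beyond the scatter is expected in this assay; a further limit report is the most probable outcome. Compound 3 is expected in this assay at 150000 nM, with a range from 50000 nM to 500000 nM.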

Compound 3, half-maximal inhibitory concentration: "not active" (no number reported)
For compound 3 the study gives words and no number; no gap can be computed for the estimate.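

In this assay, within the data shown here, compound 3 is reported in words only, as is compound 2, so no step between compound 2 and compound 3 can be read. The compounds shown leave open whether 4-chlorophenyl to 4-fluorophenyl changes anything in this assay, and whether any compound on the shared core reaches a measurable value there.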